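Replacing a side group on compound 2

A few compounds are considered here, and "the series" means these few. Any claim that something is new, unique, unknown or untested is made for them only; others in the source may bear on it.

In an ADME assay on the whole organism (plasma, strain 129/SvEvBrd x C57BL/6) for pharmacokinetics, with Mus musculus as the target, at a dose of 10 mg/kg by the oral route (a lower number here means less compound in the circulation, a higher number more compound in the circulation at the dose given), compound 1 (`CC(=O)c1nc([C@@H](O)[C@H](O)[C@H](O)CO)c(C)[nH]1`) gives a lower number (2640 ng.h/mL), and compound 2 (`CC(O)c1nc([C@@H](O)[C@H](O)[C@H](O)CO)c[nH]1`) stands highest (10300 ng.h/mL), a gap beyond the usual scatter. Compound 3 (`OC[C@@H](O)[C@@H](O)[C@H](O)c1c[nH]c(-c2cocn2)n1`) has 1,3-oxazol-4-yl in place of 1-hydroxyethyl on an aromatic carbon. For the measured compounds named here, no measured pair isolates such a replacement, so the forecast is uncertain. Going by the values given here, compound 2 (10300 ng.h/mL) holds the higher of only two values, which favours a fall over a rise. A moderate fall is expected (a 2.6-fold lower number from compound 2 to compound 3 (0.41 log units; beyond the scatter)). Compound 3 is estimated at 4000 ng.h/mL (range 1200 ng.h/mL to 13000 ng.h/mL).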

Compound 3, area under the concentration-time curve: 868 ng.h/mL
The estimate for compound 3 lay 4.6-fold (0.66 log units) above the measured number; measured number below the stated range.
By their numbers in this assay, from the lowest: compound 3; then compound 1; then compound 2.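

In this assay, 1,3-oxazol-4-yl in place of 1-hydroxyethyl on this aromatic carbon gives a 12-fold lower number from compound 2 to compound 3 (1.07 log units; beyond the scatter), so the group held here has a large bearing on the number. The change swaps an open group with a hydrogen-bond donor for an aromatic ring with none. Nothing measured here explains the drop.

Going by these compounds, whether the ring or the lost donor matters more remains open. A plain ethyl group or an aminomethyl group on this carbon would help separate the two.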